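The compounds below may be only part of what the source reports. "The series", "measured", "known", "first", "only" and "open" are said of these compounds alone.

In a functional assay on SK-OV-3 cells (Homo sapiens) for cytotoxicity, read by spectrophotometry, with a stated time of 72 h (on this read-out lower numbers stand for stronger inhibition and higher numbers for weaker inhibition), three compounds sharing one core have been measured. Compound 1 `COc1ccc(-n2c(-c3cc(OC)c(OC)c(OC)c3)cccc2=O)cc1OCc1ccccc1` gives 25500 nM, compound 3 `COc1ccc(-n2c(-c3cc(OC)c(OC)c(OC)c3)cccc2=O)cc1OC` gives 14300 nM, and compound 2 `COc1ccc(-n2c(-c3cc(OC)c(OC)c(OC)c3)cccc2=O)cc1` gives 1540 nM, the lowest number of the three. Compound 4 `COc1cc(-c2cccc(=O)n2-c2ccc(F)cc2)cc(OC)c1OC` differs from compound 2 at one place: fluoro in place of methoxy on an aromatic carbon. Among the measured compounds shown here, no measured step makes this exact swap of fluoro in place of methoxy. The closest guides are a 9.3-fold higher number from compound 2 to compound 3 (0.97 log units; beyond the scatter) and a 17-fold lower number from compound 1 to compound 2 (1.22 log units; beyond the scatter), both beyond the scatter and both made on the ring that carries the change. Each shows compound 2 with the lower number, so a rise is the likelier direction in this assay. The expected step, smaller than those two, is a 2.6-fold higher number from compound 2 to compound 4 (0.41 log units; beyond the scatter). For compound 4 the estimate is 4000 nM, with an expected range of 900 nM to 18000 nM.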

Compound 4, half-maximal inhibitory concentration: 9740 nM
The estimate for compound 4 lay 2.4-fold (0.39 log units) below the measured number; the range from low to high includes it.
By their numbers in this assay, from the lowest: compound 2; then compounds 4, 3 and 1 (each within the scatter of the next, the first and the last beyond it).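

The earlier steps shown here changed another place on this ring and kept the methoxy, whereas this one replaces the methoxy itself, turning 4-methoxyphenyl into 4-fluorophenyl. That swap gives a 6.3-fold higher number from compound 2 to compound 4 (0.80 log units; beyond the scatter), so inhibition weakens and compound 2 keeps the lowest number, which shows that this position also responds to change and that fluoro does not stand in for methoxy here. Nothing available explains the rise. Going by these compounds, whether a plain hydrogen, a hydroxyl, an amine or a longer chain such as ethoxy would lower or raise the number at this position stays open.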